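A few compounds are considered here, and "the series" means these few. Any claim that something is new, unique, unknown or untested is made for them only; others in the source may bear on it.

Acid dissociation values so far, from a physicochemical assay for acid dissociation:

- compound 1 `COc1ccc(F)cc1CNCCCNc1ccnc2cc(Cc3ccc(C#N)cc3)ccc12`: 9.47
- compound 3 `COc1cccc(CNCCCNc2ccnc3cc(Cc4ccc(C#N)cc4)ccc23)c1O`: 9.47
- compound 2 `COc1ccccc1Oc1ccc2c(NCCCNCc3ccco3)ccnc2c1`: 9.28

Compound 1 stands level with compound 3 at the digits given, the two together the highest of the three numbers; compound 2 sits lower, but by a gap within the scatter, so no order can be read among the three. Within the data shown here, the one step between neighbours, no change at the digits printed from compound 1 to compound 3 (within the scatter), exchanges the group on the saturated chain carbon bound to the amine nitrogen and leaves the read-out unchanged.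

Compound 4 `COc1ccc(F)cc1CNCCCNc1ccnc2cc(-c3ccc(C(C)(C)C)cc3)ccc12` is the next member to go into this assay. It differs from compound 1 in one place: 4-(tert-butyl)phenyl in place of 4-cyanobenzyl on an aromatic carbon

Among the measured compounds shown here, no measured step touches an aromatic carbon of the shared core, so nothing bears on this change directly. What there is points the same way: the step from compound 1 to compound 3 is flat, and compound 2, which differs from compound 1 both on the core and on the chain, still gives a value within the scatter of compound 1. The expectation for compound 4 is therefore a step of no size beyond the scatter, a number 0.02 log units lower from compound 1 to compound 4 (within the scatter). Compound 4 is estimated at 9.45, with a range from 9.15 to 9.75.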

Compound 4, acid dissociation constant: 9.47
Compound 4: the middle estimate sits 0.02 log units below what was measured; the range from low to high includes it.
By their numbers in this assay, from the lowest: compounds 2, 1, 3 and 4 (each within the scatter of the next).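

In this assay, among these compounds, the change at this aromatic carbon of the shared core gives no change at the digits printed from compound 1 to compound 4 (within the scatter) and is the first measured step at this position, where the earlier compounds offered only indirect hints. The exchange replaces 4-cyanobenzyl with 4-(tert-butyl)phenyl, so the nitrile and its hydrogen-bond acceptor leave and an all-carbon group enters, yet the read-out shows no step beyond the scatter, just as the step on the chain gives no change at the digits printed from compound 1 to compound 3 (within the scatter) for a change elsewhere in compound 1. Among the compounds shown here, no available evidence accounts for this flat result, and the two steps establish only that these particular exchanges leave the read-out where it was.

Open, as far as these compounds go, is whether any group at this aromatic carbon can move the value beyond the scatter, for instance a carboxylic acid or a primary amine on the phenyl ring in place of the tert-butyl group. Equally open, from the compounds shown here alone, is whether a longer chain between the two amine nitrogens of compound 1 would produce a step that can be read, since all four compounds so far lie within the scatter of one another.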